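The source may hold more compounds than are shown below. What is called first, only, known or untested is meant among the compounds shown, and "the series" means these compounds.

Among the compounds with values here, compound 2 `CCOc1ccc(NC(=O)c2cn(-c3ccccc3)nc2-c2ccc(OC)cc2)cc1` holds the lowest of the two numbers so far in a functional assay on HCT-116 cells (Homo sapiens) for cytotoxicity, read by MTT assay, with a stated time of 48 h (on this read-out higher numbers stand for weaker inhibition and lower numbers for stronger inhibition), where compound 2 gives 970 nM. Within the data shown here, its nearest neighbour is compound 1 `COc1ccc(-c2nn(-c3ccccc3)cc2C(=O)Nc2ccc(Br)cc2)cc1`, which in this assay gives 5870 nM; the single measured step, a 6.1-fold lower number from compound 1 to compound 2 (0.78 log units; beyond the scatter), is the replacement of bromo by ethoxy on an aromatic carbon of the aniline ring. Compound 3 `CCOc1ccc(NC(=O)c2cn(-c3ccccc3)nc2-c2ccc([N+](=O)[O-])cc2)cc1` differs from compound 2 at the other end of the molecule: nitro in place of methoxy on an aromatic carbon. Among the measured compounds shown here, no measured step touches this ring, and the one step on record concerns a different position, so it offers no direct guide. With nothing to point either way, the expectation is a change from compound 2 to compound 3 that stays within the scatter, a 1.5-fold higher number from compound 2 to compound 3 (0.19 log units; within the scatter), though a wide range is allowed. Compound 3 is therefore estimated at 1500 nM, with a plausible range from 400 nM to 6000 nM.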

Compound 3, half-maximal inhibitory concentration: 390 nM
Compound 3: the middle estimate sits 3.8-fold (0.59 log units) above what was measured; measured number below the stated range.
By their numbers in this assay, from the lowest: compound 3; then compound 2; then compound 1.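

The 4-methoxyphenyl end of the molecule, untouched by the earlier step, also responds to change in this assay, with a 2.5-fold lower number from compound 2 to compound 3 (0.40 log units; beyond the scatter) on going to 4-nitrophenyl. The number therefore moves with the group on this ring as well as with the one at the other end of the molecule, and both measured steps run towards lower numbers. Nothing available accounts for nitro giving a lower number than methoxy at this position.

The compounds shown leave open how an amine, a nitrile or a carboxylic acid would compare with nitro on this ring. They also leave open whether this step would keep its size with bromo rather than ethoxy at the other end of the molecule.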